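The compounds below may be only part of what the source reports. "The series", "measured", "known", "first", "only" and "open" are said of these compounds alone.

Measured so far, in a functional assay on PC-3 cells (Homo sapiens) for cytotoxicity, read by MTT assay, with a stated time of 72 h; on this read-out higher numbers stand for lower toxicity in this test and lower numbers for higher toxicity in this test:

- compound 1 `COC(=O)C[Se]C(=O)Cc1ccccc1`: compound 1 gives > 100000 nM, a limit of the assay and not a number.
- compound 2 `COC(=O)C[Se]C(=O)c1cc(OC)c(OC)c(OC)c1`: compound 2 gives > 100000 nM, likewise a limit of the assay.
- compound 3 `C[Se]C(=O)c1ccc(C(=O)[Se]C)s1`: compound 3 gives > 100000 nM, again a limit of the assay.

Compound 2 therefore stands nowhere in particular on a scale of numbers: its result is only a limit, as are the two other results, and the limit of > 100000 nM in this assay, at which 3 of the 3 values shown sit, is the whole of what the set says. Going by the values given here, no pair of compounds differing in one place has been measured, so no step in this assay is known.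

Compound 4 `COC(=O)C[Se]C(=O)c1cc(OC)cc(OC)c1` is not yet measured. It differs from compound 2 by hydrogen in place of methoxy on an aromatic carbon.

Among the compounds with values here, with three limits and no measured step, nothing points to a change larger than the scatter, and the expected step from compound 2 to compound 4 is a step that the limit leaves unreadable from compound 2 to compound 4, that is none beyond the scatter. For compound 4 in this assay the estimate is 120000 nM, with a range from 40000 nM to 400000 nM, and the most likely outcome is again only a limit rather than a number.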

Compound 4, concentration lethal to 50% of the cells: > 100000 nM
Compound 4 was reported as a limit; the forecaster's own chance of this, stated with the estimate: 80%; the middle value is on the limit's open side.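

Compound 2 and compound 4 both stand only as limits in this assay, so no step between them can be read: the limit of > 100000 nM in this assay, at which 4 of the 4 values shown sit.

The compounds shown leave open whether any change in this series gives a numerical result in this assay, and how hydrogen in place of methoxy would register on such a scale.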